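The compounds below may be only part of what the source reports. "The series", "measured", "known", "first", "only" and "open" are said of these compounds alone.

The three measured compounds, with their numbers in a physicochemical assay for solubility; a higher number here means a more soluble compound, a lower number a less soluble compound:

compound 1 `Cn1nccc1-c1cc(C(F)(F)F)ccc1[C@H]1CCOc2cc(S(=O)(=O)Nc3nccs3)ccc21`: 83000 nM
compound 2 `O=S(=O)(Nc1nccs1)c1ccc2c(c1)OCC[C@@H]2c1ccc(C(F)(F)F)cc1-c1ccc(F)cc1`: 39000 nM
compound 3 `Cn1nccc1-c1cc(C(F)(F)F)ccc1[C@@H]1CCOc2cc(S(=O)(=O)Nc3nccs3)ccc21`: 65000 nM

Compound 1 and compound 3 share every atom and bond; their difference is the two compounds have the same atoms and bonds and differ only in configuration as drawn: 1 of 1 stereo elements differ; a stereocentre at a saturated ring carbon is drawn R in compound 1 and S in compound 3. The step is a 1.3-fold lower number from compound 1 to compound 3 (0.11 log units; within the scatter), and because the fact that compounds 1 and 3 differ only in the configuration as drawn the two numbers are read as one level rather than a difference in solubility. Compound 2 differs from compound 1 by 4-fluorophenyl in place of 1-methyl-1H-pyrazol-5-yl on an aromatic carbon, which gave a 2.1-fold lower number from compound 1 to compound 2 (0.33 log units; beyond the scatter), a modest but real drop.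

Compound 4 `O=S(=O)(Nc1nccs1)c1ccc2c(c1)OCC[C@H]2c1ccc(C(F)(F)F)cc1-c1ccc(F)cc1` has not yet been measured in this assay. It stands to compound 3 exactly as compound 2 stands to compound 1: the change is 4-fluorophenyl in place of 1-methyl-1H-pyrazol-5-yl on an aromatic carbon, the same change at the same place, made twice among these four compounds. Since compound 1 and compound 3 sit at the same level, the step seen once is expected to repeat. The expected step is a 2.1-fold lower number from compound 3 to compound 4 (0.32 log units; beyond the scatter), resting on a 2.1-fold lower number from compound 1 to compound 2 (0.33 log units; beyond the scatter). Compound 4 is therefore estimated at 31000 nM, with a likely range from 15000 nM to 65000 nM.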

Compound 4, solubility: 147000 nM
Compound 4: middle estimate off by 4.7-fold (0.68 log units), on the low side; measured number above the stated range.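

In this assay the same replacement of 1-methyl-1H-pyrazol-5-yl by 4-fluorophenyl did not carry from one configuration of the core to the other: it gave a 2.1-fold lower number from compound 1 to compound 2 (0.33 log units; beyond the scatter) in one case and a 2.3-fold higher number from compound 3 to compound 4 (0.35 log units; beyond the scatter) in the other, so the step reversed direction. The two 4-fluorophenyl compounds stand apart by a 3.8-fold higher number from compound 2 to compound 4 (0.58 log units; beyond the scatter) while the two pyrazolyl compounds read as one level, and that gap can be laid to configuration alone: the fact that compounds 2 and 4 differ only in the configuration as drawn. A step seen on one configuration therefore cannot be assumed on the other in this series, but with a single pair on each side this does not show why the direction reversed, nor how the change would behave on a different core.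

The compounds shown leave open whether other groups on that aromatic carbon, such as an amine or a carboxylic acid, would also depend on the configuration at the saturated ring carbon. Going by these compounds, every compound here carries the trifluoromethyl group, and whether a nitrile in its place would alter the picture stays open.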